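Three dihydropyridine analogues and a fourth, yet unmeasured

The source may hold more compounds than are shown below. What is called first, only, known or untested is meant among the compounds shown, and "the series" means these compounds.

Measured compounds:
compound 1 `COC(=O)C1=C(C)N=C(C)/C(=C(\O)OC)C1c1cccc(OC(C)=O)c1`, 6030 nM
compound 2 `COC(=O)C1=C(C)N=C(C)/C(=C(\O)OC)C1c1ccccc1I`, 46.8 nM
compound 3 `COC(=O)C1=C(C)N=C(C)/C(=C(\O)OC)C1c1ccc(C#N)cc1`, 3470 nM

In a functional assay (muscle tissue) with Cavia porcellus as the target (on this read-out higher numbers stand for an effect only at larger amounts of compound and lower numbers for an effect already at smaller amounts), compound 3 stands second highest of the three numbers. Its nearest neighbour is compound 1, whose value is within the scatter of that of compound 3; furthest is compound 2, which lies far lower, as the step of a 74-fold higher number from compound 2 to compound 3 (1.87 log units; beyond the scatter) shows.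

The next compound, compound 4 `COC(=O)C1=C(C)N=C(C)/C(=C(\O)OC)C1c1cccc(C#N)c1`, keeps the shared core and the same atoms as compound 3 but joined differently: 3-cyanophenyl in place of 4-cyanophenyl on a saturated ring carbon.

Going by the values given here, no measured step exchanges 3-cyanophenyl for 4-cyanophenyl, so nothing bears on this change directly. Among the compounds with values here, the only step that touches compound 3 is a 74-fold higher number from compound 2 to compound 3 (1.87 log units; beyond the scatter), which shows that the aryl group on this saturated ring carbon can shift the read-out by a large amount. The step from compound 1 to compound 3, both with a substituted phenyl here, lies within the scatter and says nothing of direction. Given that, a moderate move downward in this assay is expected for compound 4, with wide uncertainty: the estimated step is a 4.3-fold lower number from compound 3 to compound 4 (0.64 log units; beyond the scatter).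

Compound 4 is estimated at 800 nM, expected to fall between 150 nM and 4000 nM.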

Compound 4, half-maximal effective concentration: 34.7 nM
The estimate for compound 4 lay 23-fold (1.36 log units) above the measured number; the measured number lies below the stated range.
By their numbers in this assay, from the lowest: compounds 4 and 2 (each within the scatter of the next); then compounds 3 and 1 (each within the scatter of the next).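

In this assay, going by these compounds alone, the same atoms joined differently give a 100-fold lower number from compound 3 to compound 4 (2.00 log units; beyond the scatter), so on this saturated ring carbon 3-cyanophenyl and 4-cyanophenyl are far from interchangeable, which the earlier compounds could not show. The identity of the group matters too: cyano in place of acetoxy gives a 170-fold lower number from compound 1 to compound 4 (2.24 log units; beyond the scatter), while the exchange of 2-iodophenyl for 3-cyanophenyl gives a 1.3-fold lower number from compound 2 to compound 4 (0.13 log units; within the scatter), so these two aryl groups cannot be told apart on this read-out despite their different substituents and substitution patterns. No measurement at hand accounts for any of these differences.

As far as these compounds go, only the nitrile appears here in more than one arrangement on the phenyl ring, so it remains open whether iodo or acetoxy depends as strongly on its place as the nitrile does in compound 3 and compound 4. Also open, from the compounds shown here alone, is how this assay would respond to an amine or a carboxylic acid in place of the nitrile of 3-cyanophenyl, and thus whether the low number of compound 4 is specific to the nitrile or is shared by other groups at that place.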